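The source may report more compounds than this note shows. Statements on the series, on what has been measured and on what is new or still open speak of the compounds shown alone.

Measured compounds:
compound 1, `COc1ccc(Cn2cc(CNC(=O)c3ccc([N+](=O)[O-])o3)nn2)cc1F` — 312000 nM
compound 2, `COc1cc(Cn2cc(CNC(=O)c3ccc([N+](=O)[O-])o3)nn2)ccc1O` — 224000 nM
compound 3, `COc1ccc(Cn2cc(CNC(=O)c3ccc([N+](=O)[O-])o3)nn2)cc1` — 274000 nM

In an ADME assay on Vero cells (Chlorocebus sabaeus) for cytotoxicity (on this read-out higher numbers stand for weaker inhibition and lower numbers for stronger inhibition), the three measured compounds sit close together. Compound 3 stands second highest of the three numbers; its nearest neighbour is compound 1, with a 1.1-fold lower number from compound 1 to compound 3 (0.06 log units; within the scatter), and its furthest is compound 2, with a 1.2-fold higher number from compound 2 to compound 3 (0.09 log units; within the scatter). The third measured pair gives a 1.4-fold lower number from compound 1 to compound 2 (0.14 log units; within the scatter). None of these steps reaches beyond the scatter.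

Compound 4, `O=C(NCc1cn(Cc2cccc([N+](=O)[O-])c2)nn1)c1ccc([N+](=O)[O-])o1`, is not yet measured in this assay. It differs from compound 3 by 3-nitrophenyl in place of 4-methoxyphenyl on a saturated chain carbon bound to an aromatic nitrogen. Going by the values given here, the steps that bear on this change are those on the same saturated chain carbon bound to an aromatic nitrogen, from compound 1 to compound 2 and from compound 2 to compound 3, together with the fluoro-to-hydrogen step from compound 1 to compound 3; all three are within the scatter. Among the compounds with values here, the data hold no example of a nitro group at this position, so the expectation rests on the absence of any step beyond the scatter so far.

Compound 4 is therefore expected to give 280000 nM in this assay, with a range from 140000 nM to 560000 nM. The expected step is a 1.0-fold higher number from compound 3 to compound 4 (0.01 log units; within the scatter), within the scatter.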

Compound 4, half-maximal inhibitory concentration: 326000 nM
For compound 4 the middle estimate is 1.2-fold (0.07 log units) below the measured one; the range from low to high includes it.
By their numbers in this assay, from the lowest: compounds 2, 3, 1 and 4 (each within the scatter of the next).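

In this assay, going by these compounds alone, 3-nitrophenyl on the saturated chain carbon bound to an aromatic nitrogen is the first group to replace the methoxy-bearing phenyl groups with a nitro-bearing one, yet the result is a 1.2-fold higher number from compound 3 to compound 4 (0.08 log units; within the scatter). Against the other two compounds, the change gives a 1.5-fold higher number from compound 2 to compound 4 (0.16 log units; within the scatter) and a 1.0-fold higher number from compound 1 to compound 4 (0.02 log units; within the scatter), so all four phenyl groups shown at this place remain indistinguishable on this read-out. The data shown offer no measurement that would account for this flat response.

Open, on these data alone, is whether an amine or a carboxylic acid on the phenyl ring, or a longer chain at this place, would move the number beyond the scatter. As far as these compounds go, all four compounds share the rest of the core, so the effect of changes there remains unknown.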